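Saturating the Allyl Chain of Compound 1

The compounds below may be only part of what the source reports. "The series", "measured", "known", "first", "only" and "open" are said of these compounds alone.

Compound 1 `C=CCNc1nc(NCc2ccc(C(=O)Nc3ccc(F)cc3)cc2)c2ccccc2n1` gives 11000 nM in a functional assay on SW480 cells (Homo sapiens) for inhibition, read by luminescence and resazurin assay, with a stated time of 3 days (a higher number here means a weaker inhibitor, a lower number a stronger inhibitor), the highest of the three numbers recorded. Compound 3 `CN1CCN(c2nc(NCc3ccc(NC(=O)c4ccc(F)cc4)cc3)c3ccccc3n2)CC1` gives 2500 nM and compound 2 `Cc1ccc2nc(N3CCNC(C)C3)nc(NCc3ccc(C(=O)NC4CCN(Cc5ccc(F)cc5)CC4)cc3)c2c1` gives 1000 nM, both below compound 1 by margins beyond the usual scatter. Compound 4 `CCCNc1nc(NCc2ccc(C(=O)Nc3ccc(F)cc3)cc2)c2ccccc2n1` differs from compound 1 in one place: ethyl in place of vinyl on a saturated chain carbon bound to a nitrogen on an aromatic ring. For the measured compounds named here, no step between two measured compounds isolates a change of this kind, so there is no direct precedent. Since the allylamino chain simply becomes a propylamino chain, the author expects a step from compound 1 to compound 4 of a 1.1-fold lower number from compound 1 to compound 4 (0.04 log units; within the scatter), within the scatter. Compound 4 is therefore estimated at 10000 nM, with a range from 4000 nM to 30000 nM.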

Compound 4, half-maximal inhibitory concentration: 1600 nM
Compound 4: middle estimate off by 6.3-fold (0.80 log units), on the high side, and the stated range ends above it.
By their numbers in this assay, from the lowest: compounds 2, 4 and 3 (each within the scatter of the next, the first and the last beyond it); then compound 1.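

Ethyl in place of vinyl on a saturated chain carbon bound to a nitrogen on an aromatic ring gives a 6.9-fold lower number from compound 1 to compound 4 (0.84 log units; beyond the scatter) in this assay. The number at this position therefore responds to a change that keeps the heavy-atom count and removes only the double bond outside aromatic rings, something compounds 1, 2 and 3 alone offered no single-place comparison to show. No measured evidence bears on why the step arises. On these data alone, what a butyl chain, a cyclopropylmethyl group or a chain ending in an amine would do at this position remains open.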